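Adding a second chloro to an amide at the limit

The compounds below may be only part of what the source reports. "The series", "measured", "known", "first", "only" and "open" are said of these compounds alone.

Four amides share one core and differ only in the aromatic ring joined to the carbonyl. In a functional assay on HeLa cells (Homo sapiens) for antiproliferative activity, read by MTT assay, with a stated time of 72 h (on this read-out lower numbers stand for stronger inhibition and higher numbers for weaker inhibition), compound 2 `O=C(Nc1ccc(Cl)c(-c2nnc3c(Cl)cccn23)c1)c1ccccn1` gives 75500 nM. Compound 3 `O=C(Nc1ccc(Cl)c(-c2nnc3c(Cl)cccn23)c1)c1ccc(Cl)cc1` reaches only a limit of the assay, > 100000 nM. Compound 1 `O=C(Nc1ccc(Cl)c(-c2nnc3c(Cl)cccn23)c1)c1ccc(C(F)(F)F)cc1Cl` also reaches only a limit, > 100000 nM. Among the measured compounds shown here, the single step with two measured ends, an at least 1.3-fold higher number from compound 2 to compound 3 (0.12 log units; that floor lies within the scatter), is therefore known only as a floor, and that floor lies within the usual scatter. Compound 3 thus stands at the weak end of what is shown, and the limit of > 100000 nM in this assay, at which 2 of the 3 values shown sit, is where most of this set sits.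

Compound 4 `O=C(Nc1ccc(Cl)c(-c2nnc3c(Cl)cccn23)c1)c1ccc(Cl)cc1Cl` differs from compound 3 by chloro in place of hydrogen on an aromatic carbon. For the measured compounds named here, no measured step in this set adds a chloro to this ring, so there is no number to say how large such a change is. The nearest comparison is compound 1, which also carries a second substituent on this ring and sits at a limit, > 100000 nM. Compound 4 is therefore expected to stay at or near that limit, with an expected step that the limit leaves unreadable from compound 3 to compound 4 that means nothing beyond the scatter. Compound 4 is estimated at 150000 nM, within 60000 nM to 400000 nM, and most likely reported again only as a limit.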

Compound 4, half-maximal inhibitory concentration: > 100000 nM
Compound 4: a limit, no number; the forecaster's own chance of this, stated with the estimate: 80%; the middle value is on the limit's open side.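

Compound 4, with chloro in place of hydrogen on the aromatic carbon ortho to a large group, stays at a limit of the assay, > 100000 nM. Among the compounds shown here, the steps from compound 3 to compound 4 and from compound 1 to compound 4 have limits at both ends and cannot be read, so a second chloro at this position gives no number to set against the single chloro of compound 3. For the compounds shown here, the one readable step, an at least 1.3-fold higher number from compound 2 to compound 4 (0.12 log units; that floor lies within the scatter), is only a floor and shows no change beyond the usual scatter, while the 2,4-dichlorophenyl amide joins the group of compounds that sit at the same limit: the limit of > 100000 nM in this assay, at which 3 of the 4 values shown sit.

Still open, going by these compounds, is whether an amine or a methoxy group on this same aromatic carbon would bring a measurable number in this assay, and how far past the limit compound 3 and compound 4 really lie. Compound 2 is the only one here with a measured number, and it carries a pyridin-2-yl ring, which leaves open what a chloro on that ring would do to its value.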